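Swapping the aryl group on a weakly active pyridine scaffold

The source may report more compounds than this note shows. Statements on the series, on what has been measured and on what is new or still open speak of the compounds shown alone.

Measured compounds:
compound 1, `COc1nc(-c2cc3ccccc3o2)cc(-c2ccc(Br)cc2)c1C#N`: 298000 nM
compound 2, `CCOc1nc(-c2cc3ccccc3o2)cc(-c2ccc(Br)cc2)c1C#N`: 227000 nM

In a functional assay on aorta (strain Wistar) for inhibition, with Thoracic aorta (Rattus norvegicus) as the target (on this read-out higher numbers stand for weaker inhibition and lower numbers for stronger inhibition), compound 1 gives 298000 nM, the highest of the two numbers; its nearest neighbour is compound 2 with 227000 nM, and the step of a 1.3-fold lower number from compound 1 to compound 2 (0.12 log units; within the scatter) lies within the scatter. Compound 3, `COc1nc(-c2cc3ccccc3o2)cc(-c2ccc(C)o2)c1C#N`, differs from compound 1 by 5-methylfuran-2-yl in place of 4-bromophenyl on an aromatic carbon. For the measured compounds named here, the single measured step concerns the alkoxy group and not this position, so no measured step bears on the change. With nothing to go on, compound 3 is estimated at 300000 nM, between 60000 nM and 1500000 nM, a step of a 1.0-fold higher number from compound 1 to compound 3 (0.00 log units; within the scatter) expected to be within the scatter.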

Compound 3, half-maximal inhibitory concentration: 285000 nM
Beside the measured number, compound 3's estimate is 1.1-fold (0.02 log units) above it; the range from low to high includes it.
By their numbers in this assay, from the lowest: compounds 2, 3 and 1 (each within the scatter of the next).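

In this assay, 5-methylfuran-2-yl in place of 4-bromophenyl gives a 1.0-fold lower number from compound 1 to compound 3 (0.02 log units; within the scatter) and so leaves the number unchanged within the scatter. The earlier step concerned only the alkoxy group, whereas this one shows that a six-membered aromatic ring of carbon only and a five-membered aromatic ring with a hetero atom read alike at this position. No evidence is available on what lies behind this result. Going by these compounds, whether an amine or a carboxylic acid on the aromatic ring here would bring the number beyond the scatter remains open.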